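A Hydroxy Swap on the Butyl Chain of Compound 3

The compounds below may be only part of what the source reports. "The series", "measured", "known", "first", "only" and "open" are said of these compounds alone.

Compound 1 `COc1c2ccccc2nn1C(C)C`: 704 nM
Compound 2 `COc1c2ccccc2nn1-c1cccc(I)c1`: 1660 nM
Compound 3 `CCCCn1[nH]c2ccccc2c1=O`: 792 nM

In an assay on isolated protein (urine) for inhibition of Myeloperoxidase (Homo sapiens), read by spectrophotometry (on this read-out higher numbers stand for weaker inhibition and lower numbers for stronger inhibition), compound 3 gives 792 nM, the second highest of the three numbers. It sits closest to compound 1, within the usual scatter of the measurement, and furthest from compound 2, whose number lies higher by more than the scatter. Compound 4 `O=c1c2ccccc2[nH]n1CCCO` differs from compound 3 in one place: hydroxy in place of methyl on a saturated chain carbon, three bonds along the chain from an aromatic nitrogen. For the measured compounds named here, no measured pair shows the effect of such a swap here, so the step can only be judged roughly. The expected step is a 1.3-fold higher number from compound 3 to compound 4 (0.10 log units; within the scatter), small and likely not beyond the scatter, if anything toward weaker inhibition. For compound 4 the estimate in this assay is 1000 nM, with a range from 350 nM to 3000 nM.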

Compound 4, half-maximal inhibitory concentration: 1950 nM
Compound 4: the middle estimate sits 2.0-fold (0.29 log units) below what was measured; low and high end bracket the measured number.
By their numbers in this assay, from the lowest: compounds 1 and 3 (each within the scatter of the next); then compounds 2 and 4 (each within the scatter of the next).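

Going from butyl to 3-hydroxypropyl gives a 2.5-fold higher number from compound 3 to compound 4 (0.39 log units; beyond the scatter) in this assay and so weakens inhibition. The earlier compounds shown here offered no single-place comparison, and this pair shows that the chain position responds to hydroxy in place of methyl, a change that adds one hydrogen-bond donor and one hydrogen-bond acceptor. Nothing available here explains why inhibition weakens.

As far as these compounds go, it remains open whether an amine or a carboxylic acid in place of the hydroxy would behave the same way. A longer chain carrying the hydroxy is also untested in what is shown here, so this single pair sets no trend.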